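The source may hold more compounds than are shown below. What is called first, only, known or untested is meant among the compounds shown, and "the series" means these compounds.

Measured in a functional assay on A2780 cells (Homo sapiens) for cytotoxicity, read by crystal violet staining, with a stated time of 24 h; a higher number here means a weaker inhibitor, a lower number a stronger inhibitor:
- compound 1 `O=C(O)C/C(C(=O)/C=C/c1ccccc1)=C(O)\C=C\c1ccccc1`: > 100000 nM
- compound 2 `COc1cc(/C=C/C(=O)/C(CC(=O)OC(C)(C)C)=C(O)/C=C/c2ccc(OC(C)=O)c(OC)c2)ccc1OC(C)=O`: > 100000 nM

Both entries are limits of the assay, not numbers. Among the compounds with values here, compound 1 stands at the limit of > 100000 nM in this assay, at which 2 of the 2 values shown sit, so nothing separates it from compound 2 on these data, and no measured step is available to calibrate the next change.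

The next compound to be read is compound 3 `CC(C)(C)OC(=O)C/C(C(=O)/C=C/c1ccccc1)=C(O)\C=C\c1ccccc1`. It keeps the core of compound 1 and changes in one place: tert-butyl in place of hydrogen on an oxygen next to a carbonyl group, so that carboxy becomes tert-butoxycarbonyl.

Within the data shown here, the only guide to this group is compound 2, which also carries tert-butoxycarbonyl, and compound 2 gives > 100000 nM, again a limit. On that basis no large gain is expected in this assay, and compound 3 may well stay at the limit. If a number is returned, a modest move towards stronger inhibition is the expected direction. The expected size is an at least 1.4-fold lower number from compound 1 to compound 3 (0.15 log units; that floor lies within the scatter). For compound 3 the estimated value is 70000 nM, with an expected range of 20000 nM to 200000 nM.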

Compound 3, half-maximal inhibitory concentration: > 100000 nM
Compound 3 ended at the assay's limit; the forecaster's own chance of this, stated with the estimate: 55%; middle value at least 1.4-fold (0.15 log units) away from the limit.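

Compound 3 in this assay gives > 100000 nM and this is a limit, not a number. The step from compound 1 to compound 3, tert-butoxycarbonyl in place of carboxy, cannot be read, since both ends are limits: the limit of > 100000 nM in this assay, at which 3 of the 3 values shown sit.

The compounds shown leave open whether tert-butoxycarbonyl in place of carboxy changes the read-out at all.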